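The source may hold more compounds than are shown below. What is called first, only, known or untested is meant among the compounds shown, and "the series" means these compounds.

Two compounds share one core and differ in a single group. Compound 1 `Cc1ccccc1C(=O)N(NC(=O)c1ccccc1)C(C)(C)C` is measured in an assay on cells for agonist activity at ecdysone receptor (Bombyx mori), read by a luciferase reporter, with a stated time of 24 h (on this read-out higher numbers stand for an effect only at larger amounts of compound and lower numbers for an effect already at smaller amounts), where compound 1 gives 224 nM. Compound 2 `COc1ccccc1C(=O)N(NC(=O)c1ccccc1)C(C)(C)C` carries the change (methoxy in place of methyl on an aromatic carbon), and in this assay compound 2 gives 525 nM. The result is a 2.3-fold higher number from compound 1 to compound 2 (0.37 log units; beyond the scatter).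

Compound 3 `Cc1cccc(C(=O)NN(C(=O)c2ccccc2Cl)C(C)(C)C)c1C` is built on another core; the difference between the two cores is not broken down here. In this assay compound 3 gives 20 nM, the lowest of the three numbers.

Compound 4 `COc1cccc(C(=O)NN(C(=O)c2ccccc2Cl)C(C)(C)C)c1C` has not yet been measured. It differs from compound 3 by methoxy in place of methyl on an aromatic carbon. For the measured compounds named here, this is the same kind of change as the one from compound 1 to compound 2, though not the same: there the place was ortho to a large group, here it is ortho to a methyl group and meta to a large group. The expected step is a 2.3-fold higher number from compound 3 to compound 4 (0.35 log units; beyond the scatter), because the same kind of change earlier produced a 2.3-fold higher number from compound 1 to compound 2 (0.37 log units; beyond the scatter). Compound 4 is therefore expected to give about 45 nM in this assay, most likely between 18 nM and 110 nM.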

Compound 4, half-maximal effective concentration: 15.5 nM
Beside the measured number, compound 4's estimate is 2.9-fold (0.46 log units) above it; the measured number lies below the stated range.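

In this assay, putting methoxy in place of methyl on the core of compound 3 gives a 1.3-fold lower number from compound 3 to compound 4 (0.11 log units; within the scatter), so on this core the change has no effect that can be told apart from the usual scatter of repeated measurements. Set beside the earlier step, the same kind of change did not carry over from one core to the other with the same outcome: the same change on two cores in this assay, a 2.3-fold higher number (0.37 log units; beyond the scatter) from compound 1 to compound 2 and a 1.3-fold lower number (0.11 log units; within the scatter) from compound 3 to compound 4, 3.0-fold (0.48 log units) apart, beyond the scatter of two such steps. This shows that a step seen on one core in this series is not a safe guide to the step on another, but it does not show what causes the gap, as the two pairs differ both in the core and in the surroundings of the changed place, and one pair per core gives no general rule.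

Going by these compounds, it remains open whether methoxy would behave the same way at other aromatic carbons of these cores. Also open, on these data alone, is how a longer chain such as ethoxy, or an amine, would fare at the place changed in compound 4.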